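Swapping the Ester Chain in a Dihydropyridine Acid Series

The compounds below may be only part of what the source reports. "The series", "measured", "known", "first", "only" and "open" are said of these compounds alone.

Going by the values given here, compound 3 `CC1=NC(C)=C(C(=O)O)C(c2cccc(Cl)c2)/C1=C(\O)OC/C=C/C1CCCCC1` gives 830 nM in a functional assay on IMR-32 cells for inhibition of Voltage-dependent N-type calcium channel subunit alpha-1B (Homo sapiens), read by calcium flux (on this read-out lower numbers stand for stronger inhibition and higher numbers for weaker inhibition), the lowest of the three numbers measured so far. Among the compounds with values here, compound 1 `CC1=NC(C)=C(C(=O)O)C(c2cccc(I)c2)/C1=C(\O)OC/C=C/c1ccccc1` gives 1700 nM, and compound 2 `CC1=NC(C)=C(C(=O)O)C(c2ccoc2)/C1=C(\O)OC/C=C/c1ccccc1` gives 11000 nM; the only single-point step, a 6.5-fold higher number from compound 1 to compound 2 (0.81 log units; beyond the scatter), concerns the group on the saturated ring carbon rather than the ester chain. Compound 4 `CC1=NC(C)=C(C(=O)O)C(c2cccc(Cl)c2)/C1=C(\O)OC/C(C)=C/c1ccccc1` differs from compound 3 in that chain alone: 1-methyl-2-phenylethenyl in place of 2-cyclohexylethenyl on a saturated chain carbon bound to an oxygen on an unsaturated carbon. Within the data shown here, no measured step bears on this change, and compound 1 and compound 3 differ in two places, so their two values show only that compound 1 stands higher than compound 3. He therefore expects for compound 4 a small step, a 1.6-fold higher number from compound 3 to compound 4 (0.19 log units; within the scatter), toward a weaker number. Compound 4 is estimated at 1300 nM, within 450 nM to 4000 nM.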

Compound 4, half-maximal inhibitory concentration: 680 nM
For compound 4 the middle estimate is 1.9-fold (0.28 log units) above the measured one; low and high end bracket the measured number.
By their numbers in this assay, from the lowest: compounds 4 and 3 (each within the scatter of the next); then compound 1; then compound 2.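

The step of a 1.2-fold lower number from compound 3 to compound 4 (0.09 log units; within the scatter) shows that in this assay the saturated chain carbon bound to an oxygen on an unsaturated carbon takes either 2-methyl-3-phenylprop-2-en-1-yl or 3-cyclohexylprop-2-en-1-yl without a difference beyond the scatter. The aromatic and the non-aromatic six-membered ring thus read alike here, although the methyl enters in the same swap. Nothing at hand explains this result. The compounds shown leave open what the methyl and the ring each contribute alone, and whether an amine or a longer chain at this place would read the same.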